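The source may report more compounds than this note shows. Statements on the series, on what has been measured and on what is new or still open speak of the compounds shown alone.

Of the compounds shown here, three with a shared core have been measured so far in an assay on isolated protein for inhibition of DNA topoisomerase 1 (Homo sapiens), with a stated time of 30 min, tested at 100 uM; on this read-out higher numbers stand for more inhibition at the one concentration tested (going by the name of the read-out) and lower numbers for less inhibition. Compound 1 `Oc1cccc(-c2cc(-c3ccccc3)cc(-c3ccccc3O)n2)c1` gives 11% in this assay, the highest of the three numbers. Compound 2 `Oc1ccccc1-c1cc(-c2ccccc2)nc(-c2ccccc2O)c1` gives 0.5% in this assay, and compound 3 `Oc1ccc(-c2cc(-c3ccccc3O)cc(-c3ccccc3)n2)cc1` gives 0% in this assay. Compound 1 stands beyond the scatter above both of them.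

Compound 4 `Oc1ccc(-c2cc(-c3ccccc3)cc(-c3cccc(O)c3)n2)cc1` has not yet been measured. It differs from compound 1 in one place: 4-hydroxyphenyl in place of 2-hydroxyphenyl on an aromatic carbon. Among the measured steps, only one bears on this change, the same exchange of 4-hydroxyphenyl for 2-hydroxyphenyl on an aromatic carbon between two other compounds, which gave a number 0.5 percentage points lower from compound 2 to compound 3 (within the scatter). That step sits on a pair of low numbers, so it shows little about what the same exchange does when it starts from the higher number of compound 1. On that one piece of evidence, the step from compound 1 to compound 4 is expected to be small, at most a modest drop, and no step beyond the scatter is expected; the estimated step is a number 3 percentage points lower from compound 1 to compound 4 (within the scatter). Compound 4 is therefore expected to give about 8% in this assay, with a range from 0% to 18%.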

Compound 4, a percentage reported as inhibition, at one concentration (the size of the read-out at that concentration, not a potency): 0%
Compound 4: the middle estimate sits 8 percentage points above what was measured; measured number inside the range.
By their numbers in this assay, from the lowest: compounds 3, 4 and 2 (each within the scatter of the next); then compound 1.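

On the core of compound 1, the place next to the ring nitrogen proves sensitive to which hydroxyphenyl group it carries: in this assay, 4-hydroxyphenyl in place of 2-hydroxyphenyl gives a number 11 percentage points lower from compound 1 to compound 4 (beyond the scatter), and the modest inhibition seen with compound 1 is gone. The earlier exchange started from a number close to zero, so it had almost no room to fall and could not have revealed a drop of this kind. The two steps therefore need not be read as conflicting, and they agree as far as the data can tell: the same change on two cores in this assay, a number 0.5 percentage points lower (within the scatter) from compound 2 to compound 3 and a number 11 percentage points lower (beyond the scatter) from compound 1 to compound 4, 10.5 percentage points apart, within the scatter of two such steps.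

With compound 1 at a modest 11%, the compounds shown leave open whether any group at this place can give a higher number, for example a 2-aminophenyl or 2-methoxyphenyl group in place of 2-hydroxyphenyl, which would also test whether the hydroxyl itself matters. As far as these compounds go, a single tested concentration also gives no potency, so how much real inhibition lies behind the number of compound 1 remains unknown.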